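One more methoxy on compound 3

The source may hold more compounds than are shown below. What is called first, only, known or untested is meant among the compounds shown, and "the series" means these compounds.

Of the compounds shown here, three have been measured so far in a functional assay on MCF7 cells (Homo sapiens) for cytotoxicity, read by sulforhodamine B assay, with a stated time of 48 h (on this read-out lower numbers stand for stronger inhibition and higher numbers for weaker inhibition), and they share most of their core. Compound 1 `COc1ccc(/C=C/C(=O)c2ccc(NC(C)=O)c(-c3ccc(F)cc3)c2)cc1OC` gave 15000 nM and compound 2 `COc1cc(/C=C/C(=O)c2ccc(N)c(-c3ccc(F)cc3)c2)ccc1O` gave 10500 nM and compound 3 `COc1ccc(/C=C/C(=O)c2ccc(N)c(-c3ccc(F)cc3)c2)cc1` gave 7580 nM in that test. Compound 3 stands within the usual scatter of both others, so these readings cannot be ranked.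

Compound 4 `COc1ccc(/C=C/C(=O)c2ccc(N)c(-c3ccc(F)cc3)c2)cc1OC` is compound 3 with methoxy in place of hydrogen on an aromatic carbon of a six-membered aromatic ring of carbon only, ortho to a methoxy group and meta to a large group. For the measured compounds named here, the one measured step on that ring is a 1.4-fold lower number from compound 2 to compound 3 (0.14 log units; within the scatter) and it stays within the scatter. Compound 4 shares this ring with compound 1 but differs elsewhere in the core, and compound 1 at 15000 nM also shows no gap beyond the scatter from compound 3. No step beyond the scatter is therefore expected. The estimate means a 1.3-fold higher number from compound 3 to compound 4 (0.10 log units; within the scatter) as the expected step, within the scatter. In this assay compound 4 is estimated at 9500 nM with an expected range from 4500 nM to 20000 nM across repeat measurements.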

Compound 4, half-maximal inhibitory concentration: 15000 nM
Estimate against measurement, compound 4: 1.6-fold (0.20 log units) below; measured number inside the range.
By their numbers in this assay, from the lowest: compounds 3, 2, 1 and 4 (each within the scatter of the next).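

In this assay, methoxy in place of hydrogen on this aromatic carbon gives a 2.0-fold higher number from compound 3 to compound 4 (0.30 log units; within the scatter) and so does not separate the two readings. The other two single changes leading to compound 4 also stay within the scatter: methyl in place of hydrogen on the ring oxygen gives a 1.4-fold higher number from compound 2 to compound 4 (0.15 log units; within the scatter) and hydrogen in place of acetyl on the nitrogen gives no change at the digits printed from compound 1 to compound 4 (within the scatter). Around compound 4, then, none of these three changes gives a real difference in this cell test, and no measurement on hand offers an explanation for these readings.

Still open, on these data alone, is whether another group on this aromatic carbon, such as ethoxy, chlorine or an amine, would move the number beyond the scatter. A carboxylic acid there remains equally untested among the compounds shown.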